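The compounds below may be only part of what the source reports. "The series", "measured", "known", "first", "only" and "open" are said of these compounds alone.

Compound 1, `COc1ccc(Nc2nnnn2-c2ccc(Br)cc2)cc1`, is one of three close relatives measured in an ADME assay on HaCaT cells (Homo sapiens) for cytotoxicity, read by MTT assay, with a stated time of 72 h (a lower number here means a stronger inhibitor, a higher number a weaker inhibitor), where compound 1 gives 103000 nM. Compound 2, `COc1ccc(Nc2nnnn2-c2cccc(Br)c2)cc1`, gives 107000 nM in this assay, and compound 3, `COc1ccc(Nc2nnnn2-c2ccccc2Br)cc1`, gives 105000 nM. On these numbers compound 1 stands at the low end of the set, but only nominally: the step from compound 1 to compound 2 is a 1.0-fold higher number from compound 1 to compound 2 (0.02 log units; within the scatter), the step from compound 1 to compound 3 is a 1.0-fold higher number from compound 1 to compound 3 (0.01 log units; within the scatter), and the step from compound 2 to compound 3 is a 1.0-fold lower number from compound 2 to compound 3 (0.01 log units; within the scatter). All three compounds behave alike.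

Compound 4, `COc1ccc(Nc2nnnn2-c2ccccc2F)cc1`, has not yet been measured. It differs from compound 1 in one place: 2-fluorophenyl in place of 4-bromophenyl on an aromatic nitrogen. Two things happen at once here, the halogen changes from bromine to fluorine and its place on the phenyl ring changes. The measured steps speak only to the second part; moving bromine among the three bromophenyl groups left this assay unchanged beyond the scatter in every case. Among the compounds with values here, no measured pair shows what replacing bromine with fluorine does. The expected step from compound 1 to compound 4 is therefore a 1.0-fold higher number from compound 1 to compound 4 (0.01 log units; within the scatter), essentially none. Compound 4 is expected to give 105000 nM, estimated between 60000 nM and 185000 nM.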

Compound 4, half-maximal inhibitory concentration: 122000 nM
Compound 4: the middle estimate sits 1.2-fold (0.07 log units) below what was measured, within the range that was stated.
By their numbers in this assay, from the lowest: compounds 1, 3, 2 and 4 (each within the scatter of the next).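

Within the data shown here, compound 3 and compound 4 differ only in fluoro in place of bromo on an aromatic carbon, so this pair supplies the reading of the halogen exchange that no earlier pair could give, and in this assay it amounts to a 1.2-fold higher number from compound 3 to compound 4 (0.07 log units; within the scatter) with the rest of the molecule held constant. The two steps that alter the halogen and its place together, a 1.2-fold higher number from compound 1 to compound 4 (0.07 log units; within the scatter) and a 1.1-fold higher number from compound 2 to compound 4 (0.06 log units; within the scatter) in the same assay, also stay inside the scatter, so among these four compounds neither the choice between bromine and fluorine nor the place of the halogen on the phenyl ring sets one compound apart from another. Nothing available accounts for this flat result.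

Fluorine appears here only in the 2-fluorophenyl group, so it remains open whether it would behave alike elsewhere on the phenyl ring. On these data alone, it is also open whether a group other than a halogen on that ring, such as an amine, a carboxylic acid or a longer alkyl chain, or a change to the shared core, would move the number beyond the scatter.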